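Epimer of a hydroxylated peroxide ester in HL-60 cells

This account rests on a few compounds, and the source may have more. Where it says the series, first, only, none or still open, it means among the compounds named here.

Measured compounds:
compound 1, `C=C1CCCC(C)(C)C1CC[C@]1(C)CC[C@H]([C@@H](C)C(=O)OC)OO1`, 1600 nM
compound 2, `C=C1CCCC(C)(C)C1(O)CC/C(C)=C/CC[C@]1(C)CC[C@H]([C@@H](C)C(=O)OC)OO1`, > 5000 nM

In a functional assay on HL-60 cells (Homo sapiens) for cytotoxicity, read by colony formation (a lower number here means a stronger inhibitor of growth, a higher number a weaker inhibitor of growth), compound 1 gives 1600 nM. For compound 2 this assay reports only a limit, > 5000 nM, which is a limit of the assay and not a number (the limit of > 5000 nM in this assay, at which 1 of the 2 values shown sits). Compound 2 therefore stands at the weak end of what the two measured values show, with no number to place it more closely.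

Compound 3, `C=C1CCCC(C)(C)C1(O)CC/C(C)=C/CC[C@]1(C)CC[C@@H]([C@@H](C)C(=O)OC)OO1`, differs from compound 2 in one place: the two compounds have the same atoms and bonds; at least one stereo element is drawn with a configuration in one of them and without one in the other: 1 of 5 stereo elements differ; a stereocentre at a saturated ring carbon is drawn R in compound 2 and S in compound 3. Going by the values given here, no step between two measured compounds is known here, so the weight of such a change cannot be read from the data. Compound 3 is expected to stay near the limit of compound 2, with a step that the limit leaves unreadable from compound 2 to compound 3 that could fall either side of the scatter. Compound 3 is estimated at 6000 nM in this assay, within 1500 nM to 30000 nM.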

Compound 3, concentration for 50% growth inhibition: > 5000 nM
Compound 3 gave a limit, no number (the forecaster's own chance of this, stated with the estimate: 60%); the middle value lies beyond the limit too.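

For compound 2 and compound 3 the results in this assay are both limits and not numbers, so no step between them can be read: the limit of > 5000 nM in this assay, at which 2 of the 3 values shown sit.

The compounds shown leave open whether the different configuration at the saturated ring carbon changes growth inhibition at all.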